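Changing the aryl group on the ring nitrogen

The source may report more compounds than this note shows. Statements on the series, on what has been measured and on what is new or still open speak of the compounds shown alone.

For the measured compounds named here, compound 2 `COc1ccc(F)cc1N1C(=O)CSC1c1cccc(C(=O)NCCCCc2ccccc2)c1` stands lowest of the three numbers known in a functional assay on HOS-TE85 cells (Homo sapiens) for inhibition, read by CCK-8 assay, with a stated time of 72 h (a higher number here means a weaker inhibitor, a lower number a stronger inhibitor), where compound 2 gives 8.8 nM. Compound 1 `COc1ccc(F)cc1N1C(=O)CSC1c1cccc(C(=O)NCCCCn2cccn2)c1` gives 97.3 nM, and compound 3 `Cc1ccnc(N2C(=O)CSC2c2cccc(C(=O)NCCCCn3cccn3)c2)c1` gives 19.6 nM. Two steps are known: an 11-fold lower number from compound 1 to compound 2 (1.04 log units; beyond the scatter), and a 5.0-fold lower number from compound 1 to compound 3 (0.70 log units; beyond the scatter). Compound 4 `CC(F)(F)c1cccc(N2C(=O)CSC2c2cccc(C(=O)NCCCCc3ccccc3)c2)c1` has not yet been measured; it differs from compound 2 by a group of 10 heavy atoms (8 carbon, 2 fluorine; one six-membered aromatic ring of carbon only) in place of a group of 9 heavy atoms (7 carbon, 1 oxygen, 1 fluorine; one six-membered aromatic ring of carbon only), on an amide-type nitrogen in a ring. Going by the values given here, only the step from compound 1 to compound 3 alters the group on an amide-type nitrogen in a ring, and that step was modest, so a move in either direction is possible but a large one seems unlikely. The expected result for compound 4 is 11 nM, with a range of 4 nM to 30 nM. This corresponds to an expected step of a 1.3-fold higher number from compound 2 to compound 4 (0.10 log units; within the scatter), within the scatter.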

Compound 4, half-maximal inhibitory concentration in the HOS-TE85 assay: 29.1 nM
Compound 4: middle estimate off by 2.6-fold (0.42 log units), on the low side; the range from low to high includes it.
By their numbers in the HOS-TE85 assay, from the lowest: compound 2; then compounds 3 and 4 (each within the scatter of the next); then compound 1.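

In the HOS-TE85 assay, changing the aryl group on the amide-type nitrogen in a ring gives a 3.3-fold higher number from compound 2 to compound 4 (0.52 log units; beyond the scatter), so this position also responds on the phenyl-ended chain, and here the number rises, whereas it fell in the earlier change on the pyrazole-ended chain. In a physicochemical assay for solubility, read by turbidimetry, measured as kinetic solubility, at pH 7.4 (a higher number here means a more soluble compound, a lower number a less soluble compound), compound 2 gives 10000 nM and compound 4 gives 2000 nM so the same change also lowers the reading there, and compound 4 is poorer than compound 2 on both counts: the measured solubility of compound 2, 10000 nM, and of compound 4, 2000 nM, a 5.0-fold lower number (0.70 log units; beyond the scatter)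

Going by these compounds, the two aryl groups differ in several features at once, so which feature matters stays open. Also open, on these data alone, is how a 4-methylpyridin-2-yl group, or a phenyl ring carrying an amine, would behave here on the phenyl-ended chain.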